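Phenylpiperazine variation in a phenyl-substituted imide series

This account rests on a few compounds, and the source may have more. Where it says the series, first, only, none or still open, it means among the compounds named here.

The shared core is kept throughout; the compounds differ only in the group carried on the amine nitrogen in a ring of the piperazine. Compound 1 `CC1(c2ccccc2)CC(=O)N(CC(=O)N2CCN(c3ccccc3)CC2)C1=O` is the reference member: in a functional assay on the whole organism (strain CD-1) with Mus musculus as the target, with a stated time of 2 h (on this read-out lower numbers stand for an effect already at smaller amounts and higher numbers for an effect only at larger amounts of compound), compound 1 gives 300 mg/kg. Compound 2 `CC1(c2ccccc2)CC(=O)N(CC(=O)N2CCN(c3ccc(F)cc3)CC2)C1=O` carries the 4-fluorophenyl on the same ring nitrogen, and in this assay compound 2 is recorded as "not active" (no number reported), so compound 2 stands without a number and the gap between compound 1 and compound 2 cannot be sized. Compound 3 `CC1(c2ccccc2)CC(=O)N(CC(=O)N2CCN(c3ccc(Cl)c(Cl)c3)CC2)C1=O` has not been tested. Its change from compound 2 is 3,4-dichlorophenyl in place of 4-fluorophenyl on an amine nitrogen in a ring. Within the data shown here, no measured step between two compounds is available here, so the direction of this change rests on nothing more than the two compounds already examined, of which compound 2 gave no number. Without a measured step, no size beyond the scatter can be asserted in either direction in this assay. Compound 3 is therefore expected to show a minimum effective dose of about 300 mg/kg, estimated within 100 mg/kg to 1000 mg/kg, with a considerable chance that, like compound 2, only an absence of activity is reported.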

Compound 3, minimum effective dose: "not active" (no number reported)
Compound 3: no number reported; there is nothing to compare the estimate with.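

In this assay compound 2 gives "not active" (no number reported) and compound 3 gives "not active" (no number reported), so no step can be read between them. Nothing shown gives a reason for this outcome. The compounds shown leave open how far compound 2 and compound 3 lie from compound 1, which gives 300 mg/kg.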